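Cyclohexyl in Place of Pentyl on the Acyl Carbon

The source may hold more compounds than are shown below. What is called first, only, known or untested is meant among the compounds shown, and "the series" means these compounds.

Compound 1 `CC(C)(C)N(NC(=O)c1cccc(Cl)c1)C(=O)c1ccccc1Cl`: 155 nM
Compound 2 `CCCCCC(=O)N(NC(=O)c1ccc(CC)cc1)C(C)(C)C`: 2820 nM

In an assay on cells for agonist activity at ecdysone receptor (Bombyx mori), read by a luciferase reporter, with a stated time of 24 h (on this read-out lower numbers stand for an effect already at smaller amounts and higher numbers for an effect only at larger amounts of compound), compound 2 gives 2820 nM, the higher of the two numbers recorded. Compound 1 gives 155 nM, a gap that lies beyond the scatter. Compound 3 `CCc1ccc(C(=O)NN(C(=O)C2CCCCC2)C(C)(C)C)cc1` differs from compound 2 by cyclohexyl in place of pentyl on a carbonyl carbon. Among the compounds with values here, no measured pair shows this change, so its size is unknown. Compound 3 is therefore expected close to compound 2, estimated at 2200 nM with a range from 600 nM to 8000 nM. The expected step is a 1.3-fold lower number from compound 2 to compound 3 (0.11 log units; within the scatter), no larger than the scatter.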

Compound 3, half-maximal effective concentration: 9330 nM
Beside the measured number, compound 3's estimate is 4.2-fold (0.63 log units) below it; measured number outside the range, above it.
By their numbers in this assay, from the lowest: compound 1; then compound 2; then compound 3.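

In this assay, within the data shown here, the exchange of pentyl for cyclohexyl on a carbonyl carbon gives a 3.3-fold higher number from compound 2 to compound 3 (0.52 log units; beyond the scatter) and so provides the first measured reading of this change. It shows that this position responds to the exchange, and that the ring gives a higher number than the open chain in this one pair. Nothing at hand explains the rise. Going by these compounds, whether cyclopentyl, phenyl or a longer chain such as heptyl would give a lower number remains open. So does whether the step would hold with other groups on the shared core.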